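This account rests on a few compounds, and the source may have more. Where it says the series, first, only, none or still open, it means among the compounds named here.

Measured in a functional assay on HCT-116 cells (Homo sapiens) for antiproliferative activity, read by MTT assay, with a stated time of 48 h; a lower number here means a stronger inhibitor, a higher number a weaker inhibitor:
- compound 1 `CCCCC(CCO)n1cnc2cncnc21`: > 50000 nM (a limit)
- compound 2 `CCCCCC(CCO)n1cnc2c(Cl)ncnc21`: > 50000 nM (a limit)
- compound 3 `CCCCCC(CCO)n1c(Br)nc2c(Cl)ncnc21`: 18300 nM

Among the compounds with values here, compound 3 holds the only actual number, at 18300 nM. The rest of the picture is the limit of > 50000 nM in this assay, at which 2 of the 3 values shown sit.

Next is compound 4 `CCCCCCCC(CCO)n1c(Br)nc2c(Cl)ncnc21`, which has ethyl in place of hydrogen on a saturated chain carbon, six bonds along the chain from an aromatic nitrogen. The same difference reads propyl to pentyl.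

Within the data shown here, the only measured step is an at least 2.7-fold lower number from compound 2 to compound 3 (0.43 log units; beyond the scatter). That change sits on an aromatic carbon rather than on the chain, so it serves only as a rough guide to size. Among the measured compounds shown here, no measured step isolates the chain change.

On that thin basis, a modest move to a lower number in this assay is expected, though a result within the scatter would not be surprising. The expected step is a 1.8-fold lower number from compound 3 to compound 4 (0.26 log units; within the scatter). For compound 4 the estimate is 10000 nM, with an expected range of 3500 nM to 30000 nM.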

Compound 4, half-maximal inhibitory concentration: 16200 nM
Beside the measured number, compound 4's estimate is 1.6-fold (0.21 log units) below it; the measured number falls inside the stated range.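

Within the data shown here, the step, a 1.1-fold lower number from compound 3 to compound 4 (0.05 log units; within the scatter), is the first that isolates a change on the chain, and in this assay it leaves compound 3 and compound 4 indistinguishable. Ethyl in place of hydrogen on this saturated chain carbon, six bonds along the chain from an aromatic nitrogen, therefore shows no measurable effect here, and the propyl to pentyl difference is tolerated with the number retained. The bromo step, an at least 2.7-fold lower number from compound 2 to compound 3 (0.43 log units; beyond the scatter), remains the only one beyond the scatter, and it sits on an aromatic carbon rather than on the chain, while the series still offers few actual numbers: the limit of > 50000 nM in this assay, at which 2 of the 4 values shown sit.

From the compounds shown here alone, two chain lengths on one background give no trend, so whether a longer chain would separate from compound 4 stays open. Also open, going by these compounds, is whether an amine or a carboxylic acid at this position would move the number at all.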